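A few compounds are considered here, and "the series" means these few. Any claim that something is new, unique, unknown or untested is made for them only; others in the source may bear on it.

Measured so far in a physicochemical assay for acid dissociation, using potentiometric titration:
compound 1, `COc1ccc2oc(=O)cc(CO/N=C(\C)C(C)=O)c2c1`: 5.8
compound 2, `CC(=O)/C(C)=N/OCc1cc(=O)oc2c(C)c(C)ccc12`: 5.5

Compound 1 stands at the top of these two numbers, yet compound 2 sits within the scatter of repeated measurements, so the two are not distinguished by this assay. Compound 3, `CC(=O)/C(C)=N/OCc1cc(=O)oc2ccc(Br)cc12`, has not been measured; it differs from compound 1 by bromo in place of methoxy on an aromatic carbon. Within the data shown here, no step between measured compounds is available to guide the expectation. For compound 3 a small step, downward or none beyond the scatter, is expected, a number 0.20 log units lower from compound 1 to compound 3 (within the scatter). Compound 3 is therefore estimated at 5.6, with a range from 5.1 to 6.1.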

Compound 3, acid dissociation constant: 5.4
Beside the measured number, compound 3's estimate is 0.20 log units above it; low and high end bracket the measured number.
By their numbers in this assay, from the lowest: compounds 3, 2 and 1 (each within the scatter of the next, the first and the last beyond it).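

Bromo in place of methoxy on an aromatic carbon of the shared core gives a number 0.40 log units lower from compound 1 to compound 3 (beyond the scatter) in this assay, a modest step. Among these compounds, this is the first comparison in which only one place differs, and it shows that a change at this position can register in this assay. Nothing available bears on why the number moves.
Going by these compounds, whether an amine or a carboxylic acid at this position would give a larger step, or one in the opposite direction, remains open. So does whether a longer chain in place of methoxy would do so.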